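The compounds below may be only part of what the source reports. "The series", "measured", "known", "first", "only" and "open" are said of these compounds alone.

In a functional assay on HCT-116 cells (Homo sapiens) for antiproliferative activity, read by MTT assay, with a stated time of 48 h (on this read-out higher numbers stand for weaker inhibition and lower numbers for stronger inhibition), compound 1 `CCCCCCC(CCO)n1cnc2c(Cl)ncnc21` gives 11900 nM and compound 2 `CCCCCCC(CCO)n1cnc2c(Cl)nc(Cl)nc21` gives 12100 nM, so compound 1 stands level with its nearest neighbour, with a 1.0-fold higher number from compound 1 to compound 2 (0.01 log units; within the scatter). Compound 3 `CCCCCCC(CCO)n1cnc2c(N)ncnc21` reports only a limit, > 50000 nM. Putting amino in place of chloro gave an at least 4.2-fold higher number from compound 1 to compound 3 (0.62 log units; beyond the scatter). Both steps alter the shared core and leave the chain untouched. Compound 4 `CCCCCCCCCCCCC(CCO)n1cnc2c(Cl)ncnc21` keeps the core of compound 1 and carries hexyl in place of hydrogen on a saturated chain carbon, seven bonds along the chain from an aromatic nitrogen. Within the data shown here, no measured step changes the chain, so the direction is uncertain and only a modest shift is expected. The expected result in this assay is a 1.7-fold lower number from compound 1 to compound 4 (0.23 log units; within the scatter). For compound 4 the estimated value is 7000 nM, with an expected range of 2000 nM to 25000 nM.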

Compound 4, half-maximal inhibitory concentration: > 50000 nM
Compound 4 was reported as a limit (the forecaster's own chance of this, stated with the estimate: 10%); middle value at least 7.1-fold (0.85 log units) away from the limit.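

Among these compounds, the chain, which no earlier step touched, matters in this assay: hexyl in place of hydrogen, seven bonds along the chain from an aromatic nitrogen, gives an at least 4.2-fold higher number from compound 1 to compound 4 (0.62 log units; beyond the scatter). Extending the chain therefore weakens inhibition here, so this position does not accept any added length freely. Compound 4 reports a limit, not a number, so the full size of this loss stays unknown: the limit of > 50000 nM in this assay, at which 2 of the 4 values shown sit.

Going by these compounds, a shorter chain, or one only slightly longer than in compound 1, could behave either way, so how much length is tolerated remains open. So does the effect of an amine or a carboxylic acid on the chain.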